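A few compounds are considered here, and "the series" means these few. Any claim that something is new, unique, unknown or untested is made for them only; others in the source may bear on it.

Compound 3 `CC(C)(C)c1ccc(NC(=O)c2ccc(-c3ncccc3C(=N)N)cc2)cc1` carries an amidine on the shared core, and in a functional assay for antagonist activity at transient receptor potential cation channel subfamily V member 1 (Homo sapiens), read by FLIPR (on this read-out higher numbers stand for weaker inhibition and lower numbers for stronger inhibition), compound 3 gives > 4000 nM, which is a limit of the assay rather than a number (the limit of > 4000 nM in this assay, at which 1 of the 3 values shown sits). Compound 1 `CC(C)(C)c1ccc(NC(=O)c2ccc(-c3ncccc3N(S(C)(=O)=O)S(C)(=O)=O)cc2)cc1` gives 0.8 nM in this assay, and compound 2 `CC(C)(C)c1ccc(NC(=O)c2ccc(-c3ncccc3NS(=O)(=O)c3ccccc3)cc2)cc1` gives 91 nM. The steps of an at least 5000-fold higher number from compound 1 to compound 3 (3.69 log units; beyond the scatter) and an at least 43-fold higher number from compound 2 to compound 3 (1.64 log units; beyond the scatter) show that the amidine in place of either sulfonyl group leaves almost no inhibition. Compound 4 `CC(C)(C)c1ccc(NC(=O)c2ccc(-c3ncccc3-c3nnco3)cc2)cc1` changes the same position again: a group of 5 heavy atoms (2 carbon, 2 nitrogen, 1 oxygen; one five-membered aromatic ring with 3 hetero atoms) in place of a group of 3 heavy atoms (1 carbon, 2 nitrogen; no ring), on an aromatic carbon. Within the data shown here, no measured step covers such a ring, so its effect is open; the only expectation is that it is unlikely to recover the strength of compound 1, given an at least 5000-fold higher number from compound 1 to compound 3 (3.69 log units; beyond the scatter). Compound 4 is expected near 1500 nM, between 150 nM and 10000 nM, an expected step of an at least 2.6-fold lower number from compound 3 to compound 4 (0.42 log units; beyond the scatter).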

Compound 4, half-maximal inhibitory concentration: 91 nM
Estimate against measurement, compound 4: 16-fold (1.22 log units) above; measured number below the stated range.
By their numbers in this assay, from the lowest: compound 1; then compounds 2 and 4 (each within the scatter of the next). At a limit, above all of these: compound 3.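

At this position a sulfonyl group is not needed for inhibition: 1,3,4-oxadiazol-2-yl in place of the amidine gives an at least 43-fold lower number from compound 3 to compound 4 (1.64 log units; beyond the scatter), a step measured from a limit of the assay: the limit of > 4000 nM in this assay, at which 1 of the 4 values shown sits. This ring also stands level with the (phenylsulfonyl)amino group, with no change at the digits printed from compound 2 to compound 4 (within the scatter). The bis(methylsulfonyl)amino group keeps a clear lead, with a 110-fold higher number from compound 1 to compound 4 (2.06 log units; beyond the scatter). Going by these compounds, whether a plain phenyl ring, a carboxylic acid or an amine here would match the 1,3,4-oxadiazol-2-yl stays open. On these data alone, what sets bis(methylsulfonyl)amino apart also stays open.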